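The source may hold more compounds than are shown below. What is called first, only, known or untested is meant among the compounds shown, and "the series" means these compounds.

In a functional assay, with a stated time of 10 min (on this read-out higher numbers stand for weaker inhibition and lower numbers for stronger inhibition), compound 1 `COc1cc(O)c(C(C)=O)cc1Br` gives 3000000 nM, compound 2 `CCOc1cc(OC)c(Br)cc1C(C)=O` gives 57700000 nM and compound 3 `CCCCCCCCOc1cc(OC)c(Br)cc1C(C)=O` gives 38100000 nM. These numbers place compound 2 at the weak end of this small set, level with compound 3 within the scatter. The two measured steps are a 19-fold higher number from compound 1 to compound 2 (1.28 log units; beyond the scatter), and a 1.5-fold lower number from compound 2 to compound 3 (0.18 log units; within the scatter).

Compound 4 `CCOc1cc(OC)ccc1C(C)=O` changes compound 2 in one place, with hydrogen in place of bromo on an aromatic carbon. Neither measured step removes a bromo group, so neither gives a direct size for this change, and the large first step concerns only the group on oxygen. The step is therefore expected to be a 1.2-fold lower number from compound 2 to compound 4 (0.06 log units; within the scatter), though this is uncertain. Compound 4 is estimated at 50000000 nM, with an expected range of 15000000 nM to 150000000 nM.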

Compound 4, half-maximal inhibitory concentration: 35300000 nM
The estimate for compound 4 lay 1.4-fold (0.15 log units) above the measured number, and the stated range covers the measured number.
By their numbers in this assay, from the lowest: compound 1; then compounds 4, 3 and 2 (each within the scatter of the next).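

In this assay the change from bromo to hydrogen gives a 1.6-fold lower number from compound 2 to compound 4 (0.21 log units; within the scatter) and so leaves no difference that can be read. Among these compounds, this is the first measured change on this aromatic carbon, ortho to a methoxy group, as the earlier steps altered only the group on oxygen. Nothing measured here bears on why the change has so little effect.

As far as these compounds go, whether bromo matters as little when the free hydroxyl group of compound 1 is present remains open. So does the effect of an amine or a carboxylic acid on this carbon.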